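Trifluoromethoxy for trifluoromethyl in a series without separation

The source may hold more compounds than are shown below. What is called first, only, known or untested is meant among the compounds shown, and "the series" means these compounds.

In a functional assay on DU-145 cells (Homo sapiens) for antiproliferative activity, read by propidium iodide staining, with a stated time of 96 h (a higher number here means a weaker inhibitor, a lower number a stronger inhibitor), compound 1 (`CC(O)(CSc1ccc(S(F)(F)(F)(F)F)cc1)C(=O)Nc1ccc(S(F)(F)(F)(F)F)cc1`) stands at 22300 nM and compound 2 (`CC(O)(CSc1ccc(F)cc1)C(=O)Nc1ccc(S(F)(F)(F)(F)F)cc1`) at 25400 nM on this measure. Compound 3 (`CC(O)(CSc1ccc(C(F)(F)F)cc1)C(=O)Nc1ccc(S(F)(F)(F)(F)F)cc1`) stands at 28800 nM on the same measure, within the scatter of both others, so the three show no order.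

Compound 4 (`CC(O)(CSc1ccc(OC(F)(F)F)cc1)C(=O)Nc1ccc(S(F)(F)(F)(F)F)cc1`) carries trifluoromethoxy in place of trifluoromethyl on an aromatic carbon, para to a large group (trifluoromethoxy in place of trifluoromethyl on an aromatic carbon). Among the measured compounds shown here, no measured step makes this exact change. Three measured steps do change the group at that place, and each is small: (a 1.1-fold higher number from compound 2 to compound 3 (0.05 log units; within the scatter)), (a 1.1-fold higher number from compound 1 to compound 2 (0.06 log units; within the scatter)) and (a 1.3-fold higher number from compound 1 to compound 3 (0.11 log units; within the scatter)). On that evidence, no step beyond the scatter is expected in this assay in either direction. The expected step is a 1.1-fold lower number from compound 3 to compound 4 (0.04 log units; within the scatter) in this estimate. For compound 4 the estimated value is 26000 nM with an expected range from 15000 nM to 42000 nM in this assay.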

Compound 4, half-maximal inhibitory concentration: 12500 nM
For compound 4 the middle estimate is 2.1-fold (0.32 log units) above the measured one; the measured number lies below the stated range.
By their numbers in this assay, from the lowest: compounds 4, 1, 2 and 3 (each within the scatter of the next, the first and the last beyond it).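

Working notes: this position is not silent in this assay, as trifluoromethoxy gives the first steps beyond the scatter at this place, a 2.3-fold lower number from compound 3 to compound 4 (0.36 log units; beyond the scatter) and a 2.0-fold lower number from compound 2 to compound 4 (0.31 log units; beyond the scatter), both modest. The third new step, a 1.8-fold lower number from compound 1 to compound 4 (0.25 log units; within the scatter), stays within the scatter, so the separation from the other compounds is only partial. Trifluoromethoxy in place of trifluoromethyl, on an aromatic carbon, therefore gives a step that no exchange among the earlier groups at this place gave.

Still open, on these data alone, is whether the step depends on the oxygen link or on the fluorines it carries, which a methoxy or a trifluoromethylthio group at this place would help to separate. Nothing available here bears on why the step arises.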